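Methyl Replacing Hydroxyisopropyl on the Shared Core

The compounds below may be only part of what the source reports. "The series", "measured", "known", "first", "only" and "open" are said of these compounds alone.

Compound 1 `CNc1nc2c(-c3ccnc(OC)c3)cnn2cc1OC` and compound 2 `COc1cc(-c2cnn3cc(OC)c(C(C)(C)O)nc23)ccn1` share one core and differ at a single aromatic carbon. In an assay on isolated protein for inhibition of activin receptor type-2A (Homo sapiens), read by 33P incorporation, with a stated time of 20 min, in the presence of a further agent that is not named here (on this read-out lower numbers stand for stronger inhibition and higher numbers for weaker inhibition), compound 1 gives 310 nM, while compound 2 gives 2700 nM, the highest of the two numbers; the step is an 8.7-fold higher number from compound 1 to compound 2 (0.94 log units; beyond the scatter). Compound 3 `COc1cc(-c2cnn3cc(OC)c(C)nc23)ccn1` is not yet measured. It differs from compound 2 by methyl in place of 1-hydroxy-1-methylethyl on an aromatic carbon, the site being next to the ring nitrogen and ortho to a methoxy group. Within the data shown here, no measured step carries this exact change; the only step at the same carbon, an 8.7-fold higher number from compound 1 to compound 2 (0.94 log units; beyond the scatter), shows that swapping the group there can move the number well beyond the scatter, yet it links methylamino to the group that now leaves, not to methyl. Among the measured compounds shown here, with no closer precedent, compound 3 in this assay is expected near compound 2, at 3000 nM within a wide range from 1000 nM to 10000 nM. The expected step of a 1.1-fold higher number from compound 2 to compound 3 (0.05 log units; within the scatter) therefore stays within the scatter.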

Compound 3, half-maximal inhibitory concentration: 1200 nM
The estimate for compound 3 lay 2.5-fold (0.40 log units) above the measured number; the measured number falls inside the stated range.
By their numbers in this assay, from the lowest: compound 1; then compound 3; then compound 2.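

In this assay, there is a 2.3-fold lower number from compound 2 to compound 3 (0.35 log units; beyond the scatter), so the 1-hydroxy-1-methylethyl group at this aromatic carbon is not needed to keep the number of compound 2, and the smaller methyl reads lower. Methyl does not recover the number of the methylamino compound, with a 3.9-fold higher number from compound 1 to compound 3 (0.59 log units; beyond the scatter), which places the three groups in the order methylamino, methyl, 1-hydroxy-1-methylethyl, from lowest number to highest, with every step beyond the scatter. No measurement here bears on why the three groups fall in this order.

From the compounds shown here alone, whether the lower number of compound 1 depends on the nitrogen at this carbon remains open, and an unsubstituted amine, a dimethylamino group or an ethyl group would test this. The compounds shown also leave open how a methoxy group or a longer chain at this carbon would read.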